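The source may report more compounds than this note shows. Statements on the series, on what has been measured and on what is new or still open speak of the compounds shown alone.

Among the compounds with values here, the two compounds measured so far share a core and differ only at one end. Compound 1 `CC[C@H](C)[C@H](NCC(=O)NNC(=O)COc1ccc(-c2nc3ccccc3s2)cc1OC)C(=O)O` carries the 1-carboxy-2-methylbutyl group on the amine nitrogen, and in a functional assay on HepG2 cells (Homo sapiens) for inhibition, read by MTT assay, with a stated time of 3 days (on this read-out lower numbers stand for stronger inhibition and higher numbers for weaker inhibition), compound 1 gives 3540 nM. Compound 2 `CCOC(=O)[C@H](NCC(=O)NNC(=O)COc1ccc(-c2nc3ccccc3s2)cc1OC)[C@@H](C)CC` carries the 1-(ethoxycarbonyl)-2-methylbutyl group in its place, and in this assay compound 2 gives 3970 nM. The step of a 1.1-fold higher number from compound 1 to compound 2 (0.05 log units; within the scatter) lies within the scatter, so the two numbers cannot be told apart, and compound 1 is the reference point here without being distinguishable from compound 2.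

Compound 3 `CCOC(=O)[C@@H]1CCCN1CC(=O)NNC(=O)COc1ccc(-c2nc3ccccc3s2)cc1OC` is not yet measured. It differs from compound 1 as follows: 2-(ethoxycarbonyl)pyrrolidin-1-yl in place of (1-carboxy-2-methylbutyl)amino on a saturated chain carbon bound to a carbonyl carbon. Within the data shown here, the only measured step that bears on this change is the one from compound 1 to compound 2, where the free acid became the ethyl ester without effect beyond the scatter. Among the measured compounds shown here, no measured pair speaks to closing the chain into a five-membered ring or to removing the hydrogen-bond donors, so that part of the change is untested.

The expectation is therefore a step of about a 1.2-fold higher number from compound 1 to compound 3 (0.07 log units; within the scatter), essentially no change beyond the scatter. For compound 3 the estimated value in this assay is 4200 nM, with a range from 1500 nM to 12000 nM.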

Compound 3, half-maximal inhibitory concentration: 2800 nM
Estimate against measurement, compound 3: 1.5-fold (0.18 log units) above; the measured number falls inside the stated range.
By their numbers in this assay, from the lowest: compounds 3, 1 and 2 (each within the scatter of the next).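

In this assay, putting 2-(ethoxycarbonyl)pyrrolidin-1-yl in place of the open-chain (1-carboxy-2-methylbutyl)amino gives a 1.3-fold lower number from compound 1 to compound 3 (0.10 log units; within the scatter), and the comparison with the open-chain ester gives a 1.4-fold lower number from compound 2 to compound 3 (0.15 log units; within the scatter). Earlier, only the change from free acid to ethyl ester could be read; these steps show that, on a saturated chain carbon bound to a carbonyl carbon, a group with one five-membered non-aromatic ring and 0 hydrogen-bond donors cannot be told apart from an open-chain group with 2 hydrogen-bond donors. Nothing measured here accounts for the three compounds reading alike.

On these data alone, all three values lie within the scatter of one another, so it remains open whether any group at this position can move the number beyond the scatter. Because the ring and the ester enter together relative to compound 1, their separate contributions also remain unresolved, and 2-carboxypyrrolidin-1-yl, with a carboxylic acid in place of the ethyl ester, or a six-membered piperidin-1-yl ring would be the next groups to compare.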